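Halogen swap on the aryl hydrazone: chloro to fluoro

The compounds below may be only part of what the source reports. "The series", "measured", "known", "first", "only" and "open" are said of these compounds alone.

Measured so far:
compound 1 `CN(C)CCn1cnnc1-c1cc(Oc2ccc(NC(=O)N/N=C/c3ccc(Cl)cc3)cc2F)ccn1` — 1870 nM
compound 2 `CN(C)CCn1cnnc1-c1cc(Oc2ccc(NC(=O)N/N=C/c3ccc(O)c(F)c3)cc2F)ccn1` — "not determined" (no result reported)
compound 3 `CN(C)CCn1cnnc1-c1cc(Oc2ccc(NC(=O)N/N=C/c3ccc(O)c(O)c3)cc2F)ccn1` — "not determined" (no result reported)

Among the measured compounds shown here, in an ADME assay on WI-38 cells (Homo sapiens) for cytotoxicity, read by MTT assay, with a stated time of 72 h (on this read-out higher numbers stand for weaker inhibition and lower numbers for stronger inhibition), compound 1 gives 1870 nM and is the only compound of the set with a number; compound 2 gives "not determined" (no result reported) and compound 3 gives "not determined" (no result reported). Compound 4 `CN(C)CCn1cnnc1-c1cc(Oc2ccc(NC(=O)N/N=C/c3ccc(F)cc3)cc2F)ccn1` differs from compound 1 by fluoro in place of chloro on an aromatic carbon. For the measured compounds named here, no measured pair shows what this change does in this assay, so the step is uncertain. The expected step from compound 1 to compound 4 is a 1.3-fold higher number from compound 1 to compound 4 (0.13 log units; within the scatter), within the scatter, leaning toward weaker inhibition. Compound 4 is estimated at 2500 nM, with a range of 900 nM to 7000 nM in this assay.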

Compound 4, half-maximal inhibitory concentration: 3980 nM
Compound 4: middle estimate off by 1.6-fold (0.20 log units), on the low side; the measured number falls inside the stated range.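

Among the compounds shown here, the pair gives the first readable step: in this assay the change from 4-chlorophenyl to 4-fluorophenyl gives a 2.1-fold higher number from compound 1 to compound 4 (0.33 log units; beyond the scatter) and shows that the read-out responds to the halogen at this position. The swap exchanges one heavy atom for another, with no change in hydrogen-bond donors, acceptors or net charge, yet the modest step is still visible.

Still open, on these data alone, is how a bromo, methoxy or amino group at this position would compare with chloro and fluoro. Nothing on hand explains the step.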